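The source may hold more compounds than are shown below. What is called first, only, known or untested is meant among the compounds shown, and "the series" means these compounds.

Measured in an assay on isolated protein for inhibition of Rho-associated protein kinase 2 (Homo sapiens), read by scintillation counting, radiometric assay and 33P incorporation, with a stated time of 40 min, in the presence of a further agent that is not named here; on this read-out higher numbers stand for weaker inhibition and lower numbers for stronger inhibition:

- compound 1 `CC(=O)Nc1cccc(NC(=O)COc2ccc3c(=O)ccoc3c2)c1`: 136 nM
- compound 2 `O=C(COc1ccc2c(=O)ccoc2c1)Nc1cccc(NC(=O)c2ccccc2)c1`: 16 nM
- compound 3 `N#Cc1ccc(C(=O)Nc2cccc(NC(=O)COc3ccc4c(=O)ccoc4c3)c2)cc1`: 15 nM

Compound 3 gives the lowest of the three numbers in this assay, but its nearest neighbour, compound 2, lies within the scatter of it; only compound 1 stands clearly apart, as a 9.1-fold lower number from compound 1 to compound 3 (0.96 log units; beyond the scatter) shows. The two changes that separate the measured compounds are of different kinds: the exchange of methyl for an aryl group on the carbonyl carbon, seen in an 8.5-fold lower number from compound 1 to compound 2 (0.93 log units; beyond the scatter) and a 9.1-fold lower number from compound 1 to compound 3 (0.96 log units; beyond the scatter), and the exchange on the aromatic carbon of that aryl group, seen in a 1.1-fold lower number from compound 2 to compound 3 (0.03 log units; within the scatter).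

Compound 4 `COC(=O)c1ccc(C(=O)Nc2cccc(NC(=O)COc3ccc4c(=O)ccoc4c3)c2)cc1` keeps the aryl amide and changes only the substituent on that ring: methoxycarbonyl in place of cyano on an aromatic carbon. The one step that bears on this place, a 1.1-fold lower number from compound 2 to compound 3 (0.03 log units; within the scatter), fell within the scatter, so on the numbers shown a group at this position has not moved the read-out. For the measured compounds named here, no measured step tests a methoxycarbonyl group anywhere. The step from compound 3 to compound 4 is therefore expected to be small, a 1.2-fold higher number from compound 3 to compound 4 (0.08 log units; within the scatter), with no direction beyond the scatter. In this assay compound 4 is estimated at 18 nM, with a range of 8 nM to 45 nM.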

Compound 4, half-maximal inhibitory concentration: 29 nM
Compound 4: the middle estimate sits 1.6-fold (0.21 log units) below what was measured; low and high end bracket the measured number.
By their numbers in this assay, from the lowest: compounds 3, 2 and 4 (each within the scatter of the next); then compound 1.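

At this aromatic carbon in this assay, hydrogen, cyano and methoxycarbonyl now all lie within the scatter of one another, with methoxycarbonyl compared against the other two as follows: a 1.9-fold higher number from compound 3 to compound 4 (0.29 log units; within the scatter) and a 1.8-fold higher number from compound 2 to compound 4 (0.26 log units; within the scatter) (both within the scatter). The exchange of cyano for methoxycarbonyl, a change to a group with more heavy atoms and more hydrogen-bond acceptors, therefore leaves the read-out unresolved from that of compound 3. The step away from the methyl amide also holds with this third aryl group (a 4.7-fold lower number from compound 1 to compound 4 (0.67 log units; beyond the scatter)), so all three aryl amides stand clear of compound 1.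

As far as these compounds go, whether an amine, a carboxylic acid or a longer chain at this carbon would also stay within the scatter remains open. No measured evidence is available to explain these numbers.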